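Series notes: sulfur-linked substituents on the saturated ring

This account rests on a few compounds, and the source may have more. Where it says the series, first, only, none or still open, it means among the compounds named here.

Two compounds of the shared core have numbers in an assay on SK-OV-3 cells for inhibition of eIF-2-alpha kinase GCN2 (Homo sapiens); a lower number here means a stronger inhibitor, a higher number a weaker inhibitor. Compound 1 `COCCC(=O)N[C@@H]1CC[C@@H](Nc2ncc3c(Br)nn(-c4ccc5ncccc5c4)c3n2)C1` gives 159 nM in this assay. Compound 2 `CNS(=O)(=O)[C@@H]1CC[C@@H](Nc2ncc3c(Br)nn(-c4ccc5ncccc5c4)c3n2)C1` gives 106 nM in this assay. Among the compounds with values here, the only step measured so far, a 1.5-fold lower number from compound 1 to compound 2 (0.18 log units; within the scatter), exchanged the ((2-methoxyethyl)carbonyl)amino group for methylsulfamoyl on the saturated ring carbon; the two values sit within the scatter of each other, so compound 2 cannot be set apart from compound 1 on these numbers.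

Compound 3 `COCCS(=O)(=O)N[C@@H]1CC[C@@H](Nc2ncc3c(Br)nn(-c4ccc5ncccc5c4)c3n2)C1` is not yet measured. Its change from compound 2 is ((2-methoxyethyl)sulfonyl)amino in place of methylsulfamoyl on a saturated ring carbon. The entering group carries the 2-methoxyethyl chain that compound 1 already bears, joined through a sulfonyl instead of a carbonyl, and the sulfur now sits away from the ring with the nitrogen between. Within the data shown here, the single step that bears on this, a 1.5-fold lower number from compound 1 to compound 2 (0.18 log units; within the scatter), stayed within the scatter despite replacing the whole substituent, so the expectation for a 1.2-fold higher number from compound 2 to compound 3 (0.07 log units; within the scatter) is no movement beyond the scatter in this assay. Compound 3 is therefore estimated at 125 nM, with a range from 50 nM to 320 nM.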

Compound 3, half-maximal inhibitory concentration: 262 nM
Estimate against measurement, compound 3: 2.1-fold (0.32 log units) below; the range from low to high includes it.
By their numbers in this assay, from the lowest: compounds 2, 1 and 3 (each within the scatter of the next, the first and the last beyond it).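

Working notes, position on the saturated ring carbon: this carbon can now be seen to respond beyond the scatter in this assay, which the pair of compound 1 and compound 2 did not show, since ((2-methoxyethyl)sulfonyl)amino in place of methylsulfamoyl gives a 2.5-fold higher number from compound 2 to compound 3 (0.39 log units; beyond the scatter) on a modest scale. Within the data shown here, that exchange brings in 8 heavy atoms for 5 and also puts the nitrogen, not the sulfur, on the ring carbon, so the one step holds two differences that cannot be separated here. With the 2-methoxyethyl chain held, sulfonyl in place of carbonyl on the amine nitrogen gives a 1.6-fold higher number from compound 1 to compound 3 (0.22 log units; within the scatter) and so cannot be told apart from no change on these numbers.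

Still open, from the compounds shown here alone, is whether the chain or the way the sulfonyl group is attached carries the step, which a plain methylsulfonylamino group on the same carbon would help to separate, and how a free amine or a carboxylic acid at this carbon would read. Nothing available on these compounds accounts for the step from methylsulfamoyl to the longer group.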